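The compounds below may be only part of what the source reports. "The series", "measured", "known", "first", "only" and "open" are said of these compounds alone.

In a functional assay on DU-145 cells (Homo sapiens) for cytotoxicity, read by ELISA, with a stated time of 4 days (a higher number here means a weaker inhibitor, a lower number a stronger inhibitor), compound 1 (`Cc1ccsc1-c1cc(-c2ccco2)cc(-c2ccccc2Cl)n1`) gives 29900 nM and compound 2 (`Cc1ccsc1-c1cc(-c2ccoc2)cc(-c2ccco2)n1`) gives 30400 nM while compound 3 (`Cc1ccc(-c2cc(-c3ccoc3)cc(-c3ccc(Cl)s3)n2)o1`) gives 33400 nM so that compound 3 stands level with the other two, all three lying within the scatter of one another. Compound 4 (`Cc1cccc(-c2cc(-c3ccoc3)cc(-c3ccc(Cl)s3)n2)c1`) carries 3-methylphenyl in place of 5-methylfuran-2-yl on an aromatic carbon next to the ring nitrogen (3-methylphenyl in place of 5-methylfuran-2-yl on an aromatic carbon). Within the data shown here, no measured pair isolates this swap. Compound 2 at 30400 nM and compound 3 at 33400 nM differ in more than one place yet remain level, so no step beyond the scatter is expected in this assay for this change. The expected step is a 1.3-fold lower number from compound 3 to compound 4 (0.13 log units; within the scatter) and no clear shift in either direction. Compound 4 is thus estimated at 25000 nM (expected range from 8000 nM to 70000 nM).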

Compound 4, half-maximal inhibitory concentration: 20300 nM
For compound 4 the middle estimate is 1.2-fold (0.09 log units) above the measured one, within the range that was stated.
By their numbers in this assay, from the lowest: compounds 4, 1, 2 and 3 (each within the scatter of the next).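

In this assay, among these compounds, the swap of 5-methylfuran-2-yl for 3-methylphenyl gives a 1.6-fold lower number from compound 3 to compound 4 (0.22 log units; within the scatter) and so offers the first direct reading at this aromatic carbon next to the ring nitrogen. A six-membered aromatic ring of carbon only thus stands level with the five-membered aromatic ring with 1 hetero atom in this position. No measurement shown accounts for this result. The compounds shown leave open whether an amine or a carboxylic acid on the 3-methylphenyl group, or a longer chain at this position, would give a clear step.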